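Swapping the Amine-Bearing Side Chain in Compound 1

This account rests on a few compounds, and the source may have more. Where it says the series, first, only, none or still open, it means among the compounds named here.

Of the compounds shown here, three have so far been measured in an assay on isolated protein for inhibition of ubiquitin carboxyl-terminal hydrolase 7 (Homo sapiens), read by fluorescence, with stated times of 30 min and 1 h; a higher number here means a weaker inhibitor, a lower number a stronger inhibitor. Compound 1 `Cc1cc(Cl)cc(-c2ccnc3cc(CN4C(=O)C5C(C4=O)C5(C)C)sc23)c1C[C@@H]1CNCCO1` gives 0.44 nM in this assay, the lowest of the three numbers. Compound 2 `Cc1cc(Cl)cc(-c2ccnc3cc(CN4C(=O)CCC4=O)sc23)c1CN1CCNC[C@@H]1C`, which carries a different saturated amine on the same core, gives 6.6 nM, a gap from compound 1 that is well beyond the usual scatter. Compound 3 `O=C([C@H]1Cc2cc(Cl)cc(-c3ccnc4ccsc34)c2O1)N1CCNCC1`, with a rearranged core and a simpler amide, gives 90 nM, the furthest of the three from compound 1. No two of the measured compounds differ in only one place, so none of these gaps can be tied to a single structural change.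

Compound 4 `Cc1cc(Cl)cc(-c2ccnc3cc(CN4C(=O)C5C(C4=O)C5(C)C)sc23)c1NC1CCCNC1` is not yet measured. It differs from compound 1 by (piperidin-3-yl)amino in place of (morpholin-2-yl)methyl on an aromatic carbon. Both side chains keep a secondary amine within a saturated six-membered ring, but the link to the aromatic carbon changes from a methylene to an amino group and the ring oxygen is lost. Since compound 2 shows that a different amine at this position still gives 6.6 nM, a loss beyond the scatter is plausible but a large one is not expected. Compound 4 is therefore expected to give 1.5 nM in this assay, within a range of 0.4 nM to 6 nM. The estimated step of a 3.4-fold higher number from compound 1 to compound 4 (0.53 log units; beyond the scatter) is a modest weakening.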

Compound 4, half-maximal inhibitory concentration: 0.78 nM
Estimate against measurement, compound 4: 1.9-fold (0.28 log units) above, and the stated range covers the measured number.
By their numbers in this assay, from the lowest: compounds 1 and 4 (each within the scatter of the next); then compound 2; then compound 3.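

In this assay, among the compounds shown here, the exchange of (morpholin-2-yl)methyl for (piperidin-3-yl)amino on the aromatic carbon ortho to a methyl group gives a 1.8-fold higher number from compound 1 to compound 4 (0.25 log units; within the scatter), the first comparison in this set that isolates a change in one place. It shows that, on the core of compound 1, this position accepts a replacement that alters the link to the aromatic carbon, takes away the ring oxygen, brings in a second nitrogen and leaves no defined stereocentre, all without a change beyond the scatter. Nothing measured here accounts for this result.

What the compounds shown leave open is whether the link and the ring each have no effect or have effects that offset one another, as the two change together in this step; a (piperidin-3-yl)methyl group in the same place would separate them. Also open, on these data alone, is how far the tolerance extends, and whether it would hold for an open-chain group such as 2-aminoethyl or for a group with no amine at all, such as a carboxylic acid.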